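The compounds below may be only part of what the source reports. "The series", "measured", "known", "first", "only" and "open" are said of these compounds alone.

Three compounds have been measured in a functional assay for agonist activity at Alpha-1B adrenergic receptor (Homo sapiens); on this read-out higher numbers stand for an effect only at larger amounts of compound and lower numbers for an effect already at smaller amounts:

compound 1 `CSc1ccc(F)cc1NCC1=NCCN1`: 1.86 nM
compound 2 `CS(=O)(=O)c1ccc(Cl)cc1NCC1=NCCN1`: 61.7 nM
compound 3 `Cc1ccc(S(C)(=O)=O)c(NCC2=NCCN2)c1`: 141 nM

Among these three numbers compound 2 holds the second highest place; its nearest neighbour is compound 3 and its furthest is compound 1. For the measured compounds named here, the only single-point change measured so far is methyl in place of chloro on an aromatic carbon, which gave a 2.3-fold higher number from compound 2 to compound 3 (0.36 log units; beyond the scatter), a modest shift. The account now turns to compound 4 `CSc1ccc(Cl)cc1NCC1=NCCN1`, which differs from compound 2 in one place: methylsulfanyl in place of methylsulfonyl on an aromatic carbon. Going by the values given here, no measured step isolates this exchange on its own. Compound 1 carries methylsulfanyl together with fluoro, compound 2 carries methylsulfonyl together with chloro, and a large step toward lower numbers is expected, since compound 1 gives 1.86 nM while compound 2 gives 61.7 nM and the measured change of the small group elsewhere on the ring moved the number only modestly. The expected step is a 15-fold lower number from compound 2 to compound 4 (1.19 log units; beyond the scatter). Compound 4 is estimated at 4 nM, with an expected range from 1.5 nM to 12 nM.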

Compound 4, half-maximal effective concentration: 0.501 nM
Compound 4: the middle estimate sits 8.0-fold (0.90 log units) above what was measured; the measured number lies below the stated range.
By their numbers in this assay, from the lowest: compound 4; then compound 1; then compound 2; then compound 3.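

On the aromatic carbon para to a chloro group, methylsulfanyl in place of methylsulfonyl gives a 120-fold lower number from compound 2 to compound 4 (2.09 log units; beyond the scatter) in this assay and so isolates this exchange as a large change on its own. With methylsulfanyl held in place, chloro in place of fluoro gives only a 3.7-fold lower number from compound 1 to compound 4 (0.57 log units; beyond the scatter) and shows that the low number of compound 1 does not depend on fluoro. No measurement at hand accounts for the size of either step.

The compounds shown leave open how methylsulfinyl, methoxy or a longer chain such as ethylsulfanyl would read at this position. They also leave open whether methyl in place of chloro would still bring only a modest step with methylsulfanyl on the ring.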